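A few compounds are considered here, and "the series" means these few. Any claim that something is new, unique, unknown or untested is made for them only; others in the source may bear on it.

Compound 1 `CCOC(=O)C12C(=O)OCC=C1COC2c1ccc(F)cc1` was tested in a functional assay on HeLa cells (Homo sapiens) for cytotoxicity, read by MTT assay (a lower number here means a stronger inhibitor, a higher number a weaker inhibitor), where compound 1 gives 22900 nM. Among the three compounds measured, compound 1 stands second highest. Compound 2 `CCOC(=O)C12C(=O)OCC=C1COC2c1ccc(C(C)(C)C)cc1` gives 25400 nM in this assay, and the step of a 1.1-fold higher number from compound 1 to compound 2 (0.04 log units; within the scatter) shows that tert-butyl in place of fluoro on an aromatic carbon leaves the number essentially where it was. Compound 3 `CCOC(=O)C12C(=O)OCC=C1COC2c1cc(OC)c(OC)c(OC)c1` gives 5400 nM in this assay, the lowest of the three. Compound 4 `CCOC(=O)C12C(=O)OCC=C1COC2c1ccc([N+](=O)[O-])cc1` has not yet been measured; it differs from compound 1 by nitro in place of fluoro on an aromatic carbon. Among the compounds with values here, only the step from compound 1 to compound 2 bears directly on this change, since it also replaces the same fluoro on the same aromatic carbon, and that step stayed within the scatter. Within the data shown here, compound 3 shows that a different substitution of that ring can bring a lower number, but no single step links compound 1 to compound 3, so it gives no direct guide. For compound 4 the expected step is therefore a 1.3-fold lower number from compound 1 to compound 4 (0.10 log units; within the scatter), not beyond the scatter. Compound 4 is thus estimated at 18000 nM, with a range from 6000 nM to 50000 nM.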

Compound 4, half-maximal inhibitory concentration: 53400 nM
Compound 4: middle estimate off by 3.0-fold (0.47 log units), on the low side; the measured number lies above the stated range.
By their numbers in this assay, from the lowest: compound 3; then compounds 1 and 2 (each within the scatter of the next); then compound 4.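

At this position, para to a large group, the ring substituent can move the number after all: in this assay, nitro in place of fluoro gives a 2.3-fold higher number from compound 1 to compound 4 (0.37 log units; beyond the scatter), whereas the earlier change from fluoro to tert-butyl stayed within the scatter. Nitro in place of tert-butyl gives a 2.1-fold higher number from compound 2 to compound 4 (0.32 log units; beyond the scatter), so compound 4 separates from both of the other compounds with a single group at this position, though both steps are modest. Nothing measured here explains why nitro behaves differently from fluoro and tert-butyl.

From the compounds shown here alone, with only these three groups compared directly at this position, it remains open whether the higher number is peculiar to nitro. An amine or a carboxylic acid in the same place would show whether other groups follow nitro or stay with fluoro and tert-butyl.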